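Methoxy in Place of Methyl: Expected Toxicity of Compound 4

The source may hold more compounds than are shown below. What is called first, only, known or untested is meant among the compounds shown, and "the series" means these compounds.

Measured compounds:
Compound 1 `COc1cc(O)c(C(=O)O)c(C=Cc2ccc3ccccc3c2)c1` gives 65000 nM in an ADME assay on HEK293 cells (Homo sapiens) for cytotoxicity, read by resazurin assay, with a stated time of 24 h; on this read-out higher numbers stand for lower toxicity in this test and lower numbers for higher toxicity in this test.
Compound 2 `Cc1cc(O)c(C(=O)O)c(CCc2ccc3ccccc3c2)c1` gives 40000 nM in this assay.
Compound 3 `Cc1cc(O)c(C(=O)O)c(C=Cc2ccc3ccccc3c2)c1` gives 52000 nM in this assay.

In this assay the three values stand close together; compound 2 shows the lowest number, but its gaps to compound 3 and compound 1 are within the scatter. One change is measured directly: methoxy in place of methyl on an aromatic carbon, which gave a 1.3-fold higher number from compound 3 to compound 1 (0.10 log units; within the scatter).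

Compound 4 `COc1cc(O)c(C(=O)O)c(CCc2ccc3ccccc3c2)c1` has not been measured. It differs from compound 2 by methoxy in place of methyl on an aromatic carbon, the same change, at the same place, as from compound 3 to compound 1. How the cores of compound 2 and compound 3 differ is not broken down here.

For compound 4 a step of a 1.3-fold higher number from compound 2 to compound 4 (0.10 log units; within the scatter) is expected in this assay, resting on the step of a 1.3-fold higher number from compound 3 to compound 1 (0.10 log units; within the scatter) seen for the same change. Compound 4 is therefore estimated at 50000 nM, with a likely range from 25000 nM to 100000 nM.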

Compound 4, half-maximal cytotoxic concentration: 65000 nM
Beside the measured number, compound 4's estimate is 1.3-fold (0.11 log units) below it, and the stated range covers the measured number.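

In this assay, methoxy in place of methyl on an aromatic carbon gave a 1.6-fold higher number from compound 2 to compound 4 (0.21 log units; within the scatter). Set beside the earlier step, the change carries across these two cores without a difference that can be told apart: the same change on two cores in this assay, a 1.3-fold higher number (0.10 log units; within the scatter) from compound 3 to compound 1 and a 1.6-fold higher number (0.21 log units; within the scatter) from compound 2 to compound 4, 1.3-fold (0.11 log units) apart, within the scatter of two such steps. Going by these compounds alone, this shows only that both steps stay within the scatter and agree with each other; it does not show that the change has a real effect on the read-out, or that the agreement would extend to any core beyond these two.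

The compounds shown leave open what an ethoxy group or an amine would give at this same place. They also leave open whether the change would behave alike on a core with a longer chain.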